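From carbamoyl to (morpholin-4-yl)carbonyl at the assay limit

The source may report more compounds than this note shows. Statements on the series, on what has been measured and on what is new or still open speak of the compounds shown alone.

In a functional assay with Oryctolagus cuniculus as the target (on this read-out higher numbers stand for weaker inhibition and lower numbers for stronger inhibition), compound 1 (`COc1ccc(-c2nc(/N=C(\N)N(C)C)sc2-c2ccc(OC)cc2)cc1`) gives 37 nM. Compound 2 (`C/N=C(/NC)Nc1nc(-c2ccc(OC)cc2)c(-c2ccc(OC)cc2)s1`) gives 970 nM. Compound 3 (`COc1ccc(-c2nc(C(N)=O)sc2-c2ccc(OC)cc2)cc1`) is reported as > 1000 nM, which is a limit of the assay and not a number.

The measured steps reach compound 3 through a change on an aromatic carbon. They are large for a 26-fold higher number from compound 1 to compound 2 (1.42 log units; beyond the scatter) and for an at least 27-fold higher number from compound 1 to compound 3 (1.43 log units; beyond the scatter). By contrast, an at least 1.0-fold higher number from compound 2 to compound 3 (0.01 log units; that floor lies within the scatter) has a floor within the scatter.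

Compound 4 (`COc1ccc(-c2nc(C(=O)N3CCOCC3)sc2-c2ccc(OC)cc2)cc1`) carries a different change, morpholin-4-yl in place of amino on a carbonyl carbon. Within the data shown here, no measured step alters the group on that carbonyl carbon, so these steps bear on it only indirectly. No step beyond the scatter is therefore expected in this assay, in either direction, and the limit of compound 3 at > 1000 nM remains the only anchor.

The expected change is a step that the limit leaves unreadable from compound 3 to compound 4. For compound 4 the estimated value is 2000 nM, with an expected range from 700 nM to 6000 nM.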

Compound 4, half-maximal inhibitory concentration: < 10 nM
Compound 4: only a limit was reported (the forecaster's own chance of this, stated with the estimate: 65%); at least 200-fold (2.30 log units) between middle value and limit.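

Changing the group on the carbonyl carbon has a large effect in this assay, with morpholin-4-yl in place of amino giving an at least 100-fold lower number from compound 3 to compound 4 (2.00 log units; beyond the scatter). Compound 4 is also the first compound shown to move to a lower number from the other compounds, with an at least 97-fold lower number from compound 2 to compound 4 (1.98 log units; beyond the scatter) and an at least 3.7-fold lower number from compound 1 to compound 4 (0.56 log units; beyond the scatter). The value of compound 4, < 10 nM, is a limit of the assay and not a number: the limit of < 10 nM in this assay, at which 1 of the 4 values shown sits.

From the compounds shown here alone, the true value of compound 4 therefore stays unknown, so these steps give only floors for the size of each change. Going by these compounds, it also remains open whether the morpholin-4-yl ring itself matters, or whether a piperidin-1-yl ring or an open-chain dimethylamino group on the same carbonyl carbon would give a similar read-out.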